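The source may report more compounds than this note shows. Statements on the series, on what has been measured and on what is new or still open speak of the compounds shown alone.

Compound 1 `ClCc1ccc(Cn2cnc3c(Cl)ncnc32)cc1` gave 1820 nM in a functional assay on NCI-H460 cells (Homo sapiens) for cytotoxicity, read by sulforhodamine B assay, with a stated time of 48 h; a higher number here means a weaker inhibitor of growth, a lower number a stronger inhibitor of growth. Compound 2 `Nc1nc(Cl)c2ncn(Cc3ccccc3CCl)c2n1` gave 37200 nM. Compound 3 `ClCc1ccccc1Cn1cnc2nc(Cl)nc(Cl)c21` gave 5880 nM.

Among the three measured compounds, compound 3 stands with the second highest number: compound 1 lies at a lower number, a gap beyond the scatter, while compound 2 lies at a higher number, also beyond the scatter. Compound 4 `ClCc1ccccc1Cn1cnc2ncnc(Cl)c21` has not been measured in this assay. It differs from compound 3 in one place: hydrogen in place of chloro on an aromatic carbon. Going by the values given here, no measured pair shows this exact change, so the size of the step is not known from the data. Given that compound 3 sits at 5880 nM and that the remaining compounds span a wide band around it, the step from compound 3 to compound 4 is expected to be modest, if any, with the number for compound 4 perhaps drifting somewhat upward a 1.2-fold higher number from compound 3 to compound 4 (0.08 log units; within the scatter). Compound 4 is therefore estimated at 7000 nM, with a range from 2500 nM to 20000 nM.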

Compound 4, concentration for total growth inhibition: 60300 nM
For compound 4 the middle estimate is 8.6-fold (0.94 log units) below the measured one; the whole stated range lies below it.
By their numbers in this assay, from the lowest: compound 1; then compound 3; then compounds 2 and 4 (each within the scatter of the next).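

Taking the chloro off the aromatic carbon between two ring nitrogen atoms gives the first single-place comparison in this set, and in this assay it produces a 10-fold higher number from compound 3 to compound 4 (1.01 log units; beyond the scatter), a large step. The earlier compounds shown here, which differed from one another in more than one place, could not show that this one carbon matters on its own. Going by these compounds alone, nothing measured here bears on why the loss of this one chloro moves the number so far.

On these data alone, whether a fluoro, a methyl or a methoxy group on this carbon would keep the number close to that of compound 3 or let it rise to that of compound 4 remains open. So does whether the same change would give a step of like size with the chloromethyl group placed as in compound 1.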